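Series notes: ethyl to cyclohexylmethyl on the amine

The compounds below may be only part of what the source reports. "The series", "measured", "known", "first", "only" and "open" are said of these compounds alone.

- compound 1 `CCN(C[C@H]1Cc2c(cccc2N2CCNCC2)CN1)[C@H]1CCCc2cccnc21`: 79.1%
- compound 2 `Cc1cnc2c(c1)CCC[C@@H]2N(C)C[C@H]1Cc2c(cccc2N2CCNCC2)CN1`: 47.8%

In an ADME assay on microsomes from liver (Homo sapiens) for metabolic stability, read by LC-MS, with a stated time of 10 min (on this read-out higher numbers stand for a more stable compound and lower numbers for a less stable compound), compound 1 holds the higher of the two numbers, and compound 2 sits lower by a gap beyond the scatter. Compound 3 `c1cnc2c(c1)CCC[C@@H]2N(CC1CCCCC1)C[C@H]1Cc2c(cccc2N2CCNCC2)CN1` differs from compound 1 in one place: cyclohexyl in place of methyl on a saturated chain carbon bound to an amine nitrogen. Going by the values given here, no measured pair shows this change, so the expectation is loose. A fall beyond the scatter is expected in this assay, resting only on the size of the entering group and on compound 2 at 47.8%. The expected step is a number 34.1 percentage points lower from compound 1 to compound 3 (beyond the scatter). Compound 3 is estimated at 45%, with a range of 20% to 70%.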

Compound 3, percent of the compound remaining: 81.6%
Compound 3: middle estimate off by 36.6 percentage points, on the low side; measured number outside the range, above it.
By their numbers in this assay, from the lowest: compound 2; then compounds 1 and 3 (each within the scatter of the next).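

On the saturated chain carbon bound to the amine nitrogen, cyclohexyl in place of methyl gives a number 2.5 percentage points higher from compound 1 to compound 3 (within the scatter) in this assay. This place therefore takes the six-membered carbon ring, with its 6 heavy atoms against 1, and the read-out does not separate the two compounds. Nothing measured here explains this result.

Open, on these data alone, is whether a phenyl ring, a hydroxyl group or a longer chain in the same place would also stay within the scatter of compound 1. The same question stands for cyclohexyl on a different core.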